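Cytotoxicity of pyrrolopyrimidine amines: an oxazolylmethyl replacement

This account rests on a few compounds, and the source may have more. Where it says the series, first, only, none or still open, it means among the compounds named here.

Compound 1 `CCCCNc1nc(N)nc2ccn(CCCc3ccccc3)c12` — in an ADME assay on HEK293 cells (Homo sapiens) for cytotoxicity, read by ATP content, with a stated time of 6 h (on this read-out lower numbers stand for higher toxicity in this test and higher numbers for lower toxicity in this test), compound 1 gives > 24000 nM, a limit of the assay rather than a number.
Compound 2 `CCCCNc1nc(N)nc2ccn(Cc3nccs3)c12` — in this assay compound 2 gives > 24000 nM, again a limit of the assay.
Compound 3 `COCCCNc1nc(N)nc2ccn(Cc3ccccn3)c12` — in this assay compound 3 gives > 24000 nM, also a limit of the assay.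

All three measured compounds share one core and sit at the same point, (the limit of > 24000 nM in this assay, at which 3 of the 3 values shown sit); none of them returns a number in this assay. The step that the two limits leave unreadable from compound 1 to compound 2 is therefore unreadable in size, since both ends are limits. Compound 3 thus stands where every compound here stands: at the limit, with no number of its own.

Compound 4 `Cc1coc(CNc2nc(N)nc3ccn(Cc4ccccn4)c23)n1` differs from compound 3 in one place: 4-methyl-1,3-oxazol-2-yl in place of 2-methoxyethyl on a saturated chain carbon bound to a nitrogen on an aromatic ring. For the measured compounds named here, no measured step bears directly on this change. Going by the values given here, the only step on record, the one from compound 1 to compound 2, cannot be read, and it offers no direction. With nothing beyond the scatter among the measured compounds, no step beyond the scatter is expected in this assay.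

Compound 4 is therefore expected to give about 30000 nM in this assay, most likely again reported only as a limit, with a range from 12000 nM to 100000 nM. The expected step that the limit leaves unreadable from compound 3 to compound 4 is estimated to lie within the usual scatter.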

Compound 4, half-maximal cytotoxic concentration: > 24000 nM
Compound 4 was reported as a limit; the forecaster's own chance of this, stated with the estimate: 85%; the middle value does not contradict the limit.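

Compound 3 and compound 4 both stand at a limit in this assay and neither returns a number, so the step between them cannot be read: the limit of > 24000 nM in this assay, at which 4 of the 4 values shown sit.

The compounds shown leave open whether any of them has a half-maximal cytotoxic concentration that can be given as a number, and whether 4-methyl-1,3-oxazol-2-yl in place of 2-methoxyethyl changes it at all.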